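Changing the sulfonyl substituent of compound 1

The source may report more compounds than this note shows. Statements on the series, on what has been measured and on what is new or still open speak of the compounds shown alone.

In a functional assay on K562 cells (Homo sapiens) for inhibition, read by trypan blue exclusion, with a stated time of 72 h (a higher number here means a weaker inhibitor, a lower number a stronger inhibitor), compound 1 (`Cn1c(=O)c(S(=O)(=O)Cc2ccc(F)cc2F)cc2cnc(Nc3ccc4[nH]ccc4c3)nc21`) gives 1000 nM, the lowest number of the three measured and so the strongest inhibitor so far. Compound 2 (`Cn1c(=O)c(S(=O)(=O)c2ccccc2)cc2cnc(Nc3cnc4[nH]ccc4c3)nc21`) reads 5000 nM and compound 3 (`Cn1c(=O)c(S(=O)(=O)c2ccc(F)cc2F)cc2cnc(Nc3ccncn3)nc21`) reads 30000 nM, both higher by more than the scatter.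

Compound 4 (`Cn1c(=O)c(S(=O)(=O)c2ccc(Cl)cc2)cc2cnc(Nc3ccc4[nH]ccc4c3)nc21`) has not yet been measured. It carries 4-chlorophenyl in place of 2,4-difluorobenzyl on a sulfonyl sulfur. The rest of compound 1 is unchanged.

Going by the values given here, no measured pair isolates this change, as compound 2 and compound 3 each differ from compound 1 in more than one place. The expectation in this assay is a small rise in the number, close to the edge of the scatter, and thus a slightly weaker inhibitor. Among the compounds with values here, the anchor for this expectation is compound 1 at 1000 nM, the only measured compound sharing everything else with compound 4. The estimated step is a 1.5-fold higher number from compound 1 to compound 4 (0.18 log units; within the scatter). For compound 4 the expected value is 1500 nM, with an estimated range from 400 nM to 6000 nM.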

Compound 4, half-maximal inhibitory concentration: 100 nM
Estimate against measurement, compound 4: 15-fold (1.18 log units) above, outside the stated range (below it).
By their numbers in this assay, from the lowest: compound 4; then compound 1; then compound 2; then compound 3.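

In this assay, 4-chlorophenyl in place of 2,4-difluorobenzyl on a sulfonyl sulfur gives a 10-fold lower number from compound 1 to compound 4 (1.00 log units; beyond the scatter) with the rest of the molecule unchanged. The substituent on the sulfonyl sulfur therefore moves the read-out on its own, which could not be seen from compound 2 and compound 3, as each differs from compound 1 in more than one place. No supporting data bear on why this step occurs.

The step bundles two differences, the ring substituents and the carbon link to the sulfur present in 2,4-difluorobenzyl, and the compounds shown do not separate them. On these data alone, a direct test would be 4-chlorobenzyl on the same sulfur, and whether a longer chain or an amine on that sulfur would be tolerated also stays open.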